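Methoxy on the lactam ring carbon of compound 1

A few compounds are considered here, and "the series" means these few. Any claim that something is new, unique, unknown or untested is made for them only; others in the source may bear on it.

Measured compounds:
compound 1 `CO[C@@H]1[C@@H](O)[C@@H](O)[C@H]2O[C@]1(C)n1c3ccccc3c3c4c(c5c6ccccc6n2c5c31)C(=O)NC4` — 1010 nM
compound 2 `C[C@]12O[C@H](C[C@@H](O)[C@H]1O)n1c3ccccc3c3c4c(c5c6ccccc6n2c5c31)CNC4=O` — 600 nM

In an assay on isolated protein for inhibition of protein kinase C theta type (Homo sapiens), read by HTRF (a higher number here means a weaker inhibitor, a lower number a stronger inhibitor), compound 1 gives 1010 nM, the higher of the two numbers recorded; compound 2, which shares the core but carries a different sugar-like ring and the lactam in the other orientation, gives 600 nM, and the gap between the two lies within the scatter, so no order between them can be read from these figures.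

Compound 3 `CO[C@@H]1[C@@H](O)[C@@H](O)[C@H]2O[C@]1(C)n1c3ccccc3c3c4c(c5c6ccccc6n2c5c31)C(=O)N[C@H]4OC` has not been measured. It differs from compound 1 by methoxy in place of hydrogen on a saturated ring carbon of the five-membered non-aromatic ring, next to the ring nitrogen. Within the data shown here, no pair of measured compounds shows the effect of this change, so the size of the step is open; with the two measured numbers close to each other, a step of no more than the scatter in this assay is the working assumption, with no clear direction.

Compound 3 is therefore expected to give about 1200 nM (range 400 nM to 3500 nM), which means an estimated step of a 1.2-fold higher number from compound 1 to compound 3 (0.07 log units; within the scatter).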

Compound 3, half-maximal inhibitory concentration: > 2500 nM
Compound 3: only a limit was reported; the forecaster's own chance of this, stated with the estimate: 5%; middle value at least 2.0-fold (0.31 log units) away from the limit.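

In this assay compound 3 gives > 2500 nM, which is a limit of the assay and not a number. Methoxy in place of hydrogen on a saturated ring carbon of the five-membered non-aromatic ring, next to the ring nitrogen, gives the first single-place step in the series, an at least 2.4-fold higher number from compound 1 to compound 3 (0.39 log units; beyond the scatter), so at this position the change leaves a weaker inhibitor and the step lies beyond the scatter. The step is only a lower bound on the change and its full size cannot be read: the limit of > 2500 nM in this assay, at which 1 of the 3 values shown sits.

The compounds shown leave open whether the weakening belongs to methoxy in particular or would also follow from another group on this carbon, such as a hydroxyl, an amine or a longer chain like ethoxy. They also leave open how the opposite configuration at this carbon would read in this assay, and whether the same change would give a step of similar direction on the core of compound 2, with its different sugar-like ring and reversed lactam.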